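Fluorine on the Phenyl: Small Step Expected

The source may report more compounds than this note shows. Statements on the series, on what has been measured and on what is new or still open speak of the compounds shown alone.

Compound 2 `COc1ccc(-n2nc(-c3ccccc3)cc2-c2ccc3cc(F)ccc3n2)cc1` stands highest of the two numbers measured in an ADME assay on Huh-7 cells (Homo sapiens) for cytotoxicity, read by XTT assay, with a stated time of 3 days, tested at 20 uM (a lower number here means a stronger effect, a higher number a weaker effect of the compound at the concentration tested), where compound 2 gives 116%. Its nearest neighbour, compound 1 `Fc1ccc(-c2cc(-c3ccc4cc(F)ccc4n3)n(-c3ccccc3)n2)cc1`, gives 88.1% in this assay, a gap beyond the usual scatter. For the measured compounds named here, no step between the measured compounds differing in one place is available. Compound 3 `COc1ccc(-n2nc(-c3ccc(F)cc3)cc2-c2ccc3cc(F)ccc3n2)cc1` differs from compound 2 by fluoro in place of hydrogen on an aromatic carbon. The step of a number 8 percentage points lower from compound 2 to compound 3 (within the scatter) is expected to fall within the scatter, with no clear direction. Compound 3 is therefore estimated at 108% in this assay, within a range from 88% to 125%.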

Compound 3, a percentage reported as activity, at one concentration (the size of the read-out at that concentration, not a potency): 89.1%
The estimate for compound 3 lay 18.9 percentage points above the measured number; the range from low to high includes it.
By their numbers in this assay, from the lowest: compounds 1 and 3 (each within the scatter of the next); then compound 2.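

In this assay the change from phenyl to 4-fluorophenyl gives a number 26.9 percentage points lower from compound 2 to compound 3 (beyond the scatter), so a single fluoro at this position can move the read-out in the methoxy-bearing series. With that fluoro already present, the added methoxy gives a number 1 percentage points higher from compound 1 to compound 3 (within the scatter), and the two compounds stand level. Nothing at hand accounts for either step. The compounds shown leave open whether chloro, a nitrile or an amine in place of the fluoro would give a similar step. They also leave open whether the fluoro step would recur on a core lacking the methoxy.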